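The compounds below may be only part of what the source reports. "The series", "measured", "known", "first", "only" and "open" are said of these compounds alone.

Of the compounds shown here, three have been measured in a functional assay on A549 cells (Homo sapiens) for antiproliferative activity, read by MTT assay, with a stated time of 48 h; on this read-out lower numbers stand for stronger inhibition and higher numbers for weaker inhibition.

Compound 1, `COc1ccc2[nH]c(-c3cn(-c4ccccc4)nc3-c3ccc(F)cc3)nc2c1`, gives 1960 nM.
Compound 2, `Fc1ccc(-c2nn(-c3ccccc3)cc2-c2nc3cc(C(F)(F)F)ccc3[nH]2)cc1`, gives 2340 nM.
Compound 3, `COc1ccc2[nH]c(-c3cn(-c4ccccc4)nc3-c3ccc(Cl)cc3)nc2c1`, gives 2420 nM.

All three share one core; they differ only in the groups hung on it. Compound 2 arises from compound 1 by one change, (trifluoromethyl in place of methoxy on an aromatic carbon), and that change moved the read-out by a 1.2-fold higher number from compound 1 to compound 2 (0.08 log units; within the scatter). Compound 3 arises from compound 1 by a different change, (chloro in place of fluoro on an aromatic carbon), with a step of a 1.2-fold higher number from compound 1 to compound 3 (0.09 log units; within the scatter).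

Compound 4, `FC(F)(F)c1ccc2[nH]c(-c3cn(-c4ccccc4)nc3-c3ccc(Cl)cc3)nc2c1`, has not yet been measured. It arises from compound 3 by trifluoromethyl in place of methoxy on an aromatic carbon. This is the same change already seen between compound 1 and compound 2, at the same place on the core. Within the data shown here, the only other difference between the two pairs is the one that sets compound 3 apart from compound 1, and that one hardly moved the read-out.

Resting on the step from compound 1 to compound 2, the step from compound 3 to compound 4 is expected to be about a 1.2-fold higher number from compound 3 to compound 4 (0.08 log units; within the scatter). Compound 4 is therefore estimated at 2900 nM, expected to fall between 1500 nM and 5600 nM.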

Compound 4, half-maximal inhibitory concentration: 3360 nM
For compound 4 the middle estimate is 1.2-fold (0.06 log units) below the measured one, within the range that was stated.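

In this assay, putting trifluoromethyl in place of methoxy on the chloro compound gives a 1.4-fold higher number from compound 3 to compound 4 (0.14 log units; within the scatter), and this swap carries over from one core to the other with no difference that can be told apart: the same change on two cores in this assay, a 1.2-fold higher number (0.08 log units; within the scatter) from compound 1 to compound 2 and a 1.4-fold higher number (0.14 log units; within the scatter) from compound 3 to compound 4, 1.2-fold (0.07 log units) apart, within the scatter of two such steps. Putting chloro in place of fluoro, with trifluoromethyl already present, gives a 1.4-fold higher number from compound 2 to compound 4 (0.16 log units; within the scatter), and this swap carries over in the same way: the same change on two cores in this assay, a 1.2-fold higher number (0.09 log units; within the scatter) from compound 1 to compound 3 and a 1.4-fold higher number (0.16 log units; within the scatter) from compound 2 to compound 4, 1.2-fold (0.07 log units) apart, within the scatter of two such steps. Among these compounds, all four steps lie within the scatter, so the agreement shows only that neither swap moved the read-out measurably on these cores; it does not show that the two swaps add up exactly, or that the steps would stay this small on a core carrying other groups.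

The compounds shown leave open whether another kind of group on the same aromatic carbon, such as an amine or a carboxylic acid, would move the read-out beyond the scatter. As far as these compounds go, it is equally open whether a hydroxyl or a longer chain in place of the fluoro or chloro would do so.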